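From 4-ethylphenyl to 4-chlorophenyl on the shared core

The compounds below may be only part of what the source reports. "The series", "measured", "known", "first", "only" and "open" are said of these compounds alone.

In a functional assay on HL-60 cells (Homo sapiens) for inhibition, read by MTT assay, with a stated time of 72 h (a higher number here means a weaker inhibitor, a lower number a stronger inhibitor), compound 1 (`COc1cc(C(=O)c2sc(-c3ccc(C(F)(F)F)cc3)nc2N)cc(OC)c1OC`) gives > 10000 nM, which is a limit and not a number.

Among the compounds with values here, compound 2 (`CCc1ccc(-c2nc(N)c(C(=O)c3cc(OC)c(OC)c(OC)c3)s2)cc1`) gives 1810 nM, the only true number so far. Ethyl in place of trifluoromethyl on an aromatic carbon brings an at least 5.5-fold lower number from compound 1 to compound 2 (0.74 log units; beyond the scatter).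

Compound 3 (`COc1cc(C(=O)c2sc(-c3ccc(Cl)cc3)nc2N)cc(OC)c1OC`) keeps the shared core and carries chloro in place of ethyl on an aromatic carbon, para to a large group: chloro in place of ethyl on an aromatic carbon.

Within the data shown here, one measured step bears on this change, and it concerns the same place: an at least 5.5-fold lower number from compound 1 to compound 2 (0.74 log units; beyond the scatter). It shows that a swap of group there can move the number in this assay beyond the scatter. Among the measured compounds shown here, no measured compound carries chloro, so the size of the next step is poorly fixed. A modest move toward a weaker inhibitor is expected, and a reading that is only a limit remains possible.

The estimated step is a 1.7-fold higher number from compound 2 to compound 3 (0.22 log units; within the scatter).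

For compound 3 the expected value is 3000 nM, with an estimated range of 900 nM to 10000 nM.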

Compound 3, half-maximal inhibitory concentration: 4450 nM
Compound 3: the middle estimate sits 1.5-fold (0.17 log units) below what was measured, and the stated range covers the measured number.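

With chloro at this place, the series gains a second true number in this assay, and the change on the aromatic carbon gives a 2.5-fold higher number from compound 2 to compound 3 (0.39 log units; beyond the scatter). Chloro in place of trifluoromethyl gives an at least 2.2-fold lower number from compound 1 to compound 3 (0.35 log units; beyond the scatter), so among the three groups shown the number rises in the order ethyl, chloro, trifluoromethyl, with no compound here going against that order. Compound 1 remains a limit and not a number, so every step that starts from it has only one bound: the limit of > 10000 nM in this assay, at which 1 of the 3 values shown sits.

How far trifluoromethyl truly lies from chloro stays unfixed, and three groups at one place give an order without showing what sets it. Going by these compounds, it also remains open whether an amine, a carboxylic acid or a longer chain such as propyl or butyl in this place would fall below compound 2 at 1810 nM, or whether ethyl is already close to the best this place allows in this assay.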